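Same Amide Aryl Change Carried onto a Second Core

The source may report more compounds than this note shows. Statements on the series, on what has been measured and on what is new or still open speak of the compounds shown alone.

Compound 1 `COc1cc(-c2nn(-c3ccc(NC(=O)c4cc(Cl)cc(Cl)c4)cc3)cc2-c2ccncc2)ccc1Cl` gives 12000 nM in a functional assay on SK-MEL-5 cells (Homo sapiens) for antiproliferative activity, read by sulforhodamine B assay, with a stated time of 48 h; a lower number here means a stronger inhibitor, a higher number a weaker inhibitor. Compound 2 `COc1cc(-c2nn(-c3ccc(NC(=O)c4ccc(Cl)c(C(F)(F)F)c4)cc3)cc2-c2ccncc2)ccc1Cl` gives 1590 nM in this assay; the change 4-chloro-3-(trifluoromethyl)phenyl in place of 3,5-dichlorophenyl on a carbonyl carbon produced the step of a 7.5-fold lower number from compound 1 to compound 2 (0.88 log units; beyond the scatter). Compound 3 `O=C(Nc1ccc(-n2cc(-c3ccncc3)c(-c3ccc(Cl)c(O)c3)n2)cc1)c1cc(Cl)cc(Cl)c1` gives 1400 nM in this assay. Its core differs from the core of compound 1 by hydrogen in place of methyl on an oxygen on an aromatic ring, and that step was an 8.6-fold lower number from compound 1 to compound 3 (0.93 log units; beyond the scatter). Compound 2 and compound 3 sit within the usual scatter of each other.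

Compound 4 `O=C(Nc1ccc(-n2cc(-c3ccncc3)c(-c3ccc(Cl)c(O)c3)n2)cc1)c1ccc(Cl)c(C(F)(F)F)c1` has not been measured. It differs from compound 3 by 4-chloro-3-(trifluoromethyl)phenyl in place of 3,5-dichlorophenyl on a carbonyl carbon, the same change at the same place as from compound 1 to compound 2. Compound 4 is expected to give about 300 nM in this assay, likely between 100 nM and 900 nM. The expected step of a 4.7-fold lower number from compound 3 to compound 4 (0.67 log units; beyond the scatter) is taken somewhat smaller than the earlier one because a 7.5-fold lower number from compound 1 to compound 2 (0.88 log units; beyond the scatter) was measured on the weaker core of compound 1, and two gains of this size need not add fully.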

Compound 4, half-maximal inhibitory concentration: 1070 nM
Compound 4: the middle estimate sits 3.6-fold (0.55 log units) below what was measured, outside the stated range (above it).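

In this assay, the amide aryl change did not carry over to the core of compound 3 at its earlier size, giving only a 1.3-fold lower number from compound 3 to compound 4 (0.12 log units; within the scatter): the same change on two cores in this assay, a 7.5-fold lower number (0.88 log units; beyond the scatter) from compound 1 to compound 2 and a 1.3-fold lower number (0.12 log units; within the scatter) from compound 3 to compound 4, 5.8-fold (0.76 log units) apart, beyond the scatter of two such steps Read the other way, hydrogen in place of methyl on the oxygen gave a 1.5-fold lower number from compound 2 to compound 4 (0.17 log units; within the scatter), so the two changes did not add up in compound 4: the same change on two cores in this assay, an 8.6-fold lower number (0.93 log units; beyond the scatter) from compound 1 to compound 3 and a 1.5-fold lower number (0.17 log units; within the scatter) from compound 2 to compound 4, 5.8-fold (0.76 log units) apart, beyond the scatter of two such steps This holds for one pair of cores and one pair of amide aryl groups, and it does not show why the steps differ or whether other groups would behave alike.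

The compounds shown leave open what an amine or a carboxylic acid on the amide aryl ring would do on either core. They also leave open how a longer chain on that oxygen would compare.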